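The source may hold more compounds than are shown below. What is called first, only, known or untested is meant among the compounds shown, and "the series" means these compounds.

Working notes on the series. All four compounds share one core, shown for compound 1 `Nc1cc(N)c2nc(-c3ccccc3)c(NCc3ccc(Cl)c(Cl)c3)nc2c1`, and differ only in the benzyl group on the ring nitrogen. In a functional assay on MCF7 cells (Homo sapiens) for inhibition, read by sulforhodamine B assay, with a stated time of 48 h (a lower number here means a stronger inhibitor of growth, a higher number a weaker inhibitor of growth), compound 1 gives 53700 nM. Compound 2 `COc1ccc(CNc2nc3cc(N)cc(N)c3nc2-c2ccccc2)cc1OC` carries the 3,4-dimethoxyphenyl group in place of the 3,4-dichlorophenyl group. For compound 2 this assay reports only a limit, < 100000 nM. Compound 3 `Nc1cc(N)c2nc(-c3ccccc3)c(NCc3ccc(F)cc3)nc2c1` carries the 4-fluorophenyl group. For compound 3 this assay likewise reports only a limit, < 100000 nM. Compound 3 thus stands on no number of its own, but on the limit at which two of the three values sit (the limit of < 100000 nM in this assay, at which 2 of the 3 values shown sit).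

Compound 4 `COc1ccc(CNc2nc3cc(N)cc(N)c3nc2-c2ccccc2)cc1` differs from compound 3 by methoxy in place of fluoro on an aromatic carbon. Within the data shown here, the measured steps that touch this position are a step that the limit leaves unreadable from compound 1 to compound 3 and a step that the two limits leave unreadable from compound 2 to compound 3, together with a step that the limit leaves unreadable from compound 1 to compound 2; none of the three can be read in size, so no measured step gives a size to carry over to the exchange of fluoro for methoxy. Among the measured compounds shown here, the only number in the set is that of compound 1, 53700 nM, and the exchange is expected to give a step that the limit leaves unreadable from compound 3 to compound 4, none beyond the scatter. For compound 4 the value in this assay is estimated at 60000 nM, within a range from 20000 nM to 100000 nM.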

Compound 4, concentration for total growth inhibition: 26300 nM
Compound 4: middle estimate off by 2.3-fold (0.36 log units), on the high side; the range from low to high includes it.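

The benzyl position now carries one readable step in this assay, a 2.0-fold lower number from compound 1 to compound 4 (0.31 log units; beyond the scatter), with the 4-methoxyphenyl group in place of the 3,4-dichlorophenyl group. Among these compounds, this shows that a change at this position can move the number beyond the scatter, which the earlier compounds, with only one number among them, could not show. The step is modest and exchanges the whole substituted phenyl group, so it does not say which substituent accounts for it, and the other steps to compound 4 cannot be read, because compound 2 and compound 3 each rest on a limit: the limit of < 100000 nM in this assay, at which 2 of the 4 values shown sit.

From the compounds shown here alone, the size of the exchange of fluoro for methoxy therefore stays open, as does the effect of the second methoxy group that separates compound 2 from compound 4. Also open, going by these compounds, is how the number would respond to an amine or a carboxylic acid on the phenyl ring, or to a longer chain in place of the benzyl group.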